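This account rests on a few compounds, and the source may have more. Where it says the series, first, only, none or still open, it means among the compounds named here.

Measured in a functional assay on MCF7 cells (Homo sapiens) for inhibition, read by fluorescence, with a stated time of 72 h; a lower number here means a stronger inhibitor of growth, a higher number a weaker inhibitor of growth:
compound 1 `CC(C)c1nccc2nn(-c3ccccc3)cc12` gives 98800 nM
compound 2 `CCCCc1cc2nn(-c3ccccc3)cc2c(C(C)C)n1` gives 33300 nM
compound 3 `CCCCc1cc2nn(-c3ccccc3)cc2cn1` gives 13300 nM

Compound 2 holds the second highest of the three numbers in this assay. Its nearest neighbour is compound 3, reached by a 2.5-fold lower number from compound 2 to compound 3 (0.40 log units; beyond the scatter); the furthest is compound 1, from which compound 2 is reached by a 3.0-fold lower number from compound 1 to compound 2 (0.47 log units; beyond the scatter). Both steps are modest and both lie beyond the scatter.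

Compound 4 `CC(C)c1nc(-c2ccccc2)cc2nn(-c3ccccc3)cc12` is not yet measured. It differs from compound 2 in one place: phenyl in place of butyl on an aromatic carbon. Among the measured compounds shown here, of the measured steps, only the one from compound 1 to compound 2 touches the same carbon, and it shows that filling that carbon with a butyl chain gives a lower number. For the measured compounds named here, no measured pair shows a phenyl at that carbon, so the size of the step from butyl to phenyl cannot be read directly from the series; the isopropyl group stays in place, as it does in compound 1 and compound 2.

On that basis compound 4 is expected to stay close to compound 2, with the step of a 1.7-fold lower number from compound 2 to compound 4 (0.22 log units; within the scatter) expected to be modest and its direction uncertain. The estimate for compound 4 in this assay is 20000 nM, with a range from 5000 nM to 80000 nM.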

Compound 4, concentration for 50% growth inhibition: 91000 nM
Compound 4: the middle estimate sits 4.6-fold (0.66 log units) below what was measured, and the stated range ends below it.
By their numbers in this assay, from the lowest: compound 3; then compound 2; then compounds 4 and 1 (each within the scatter of the next).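

At the aromatic carbon next to the ring nitrogen, the identity of the group counts and not merely the filling of the position: in this assay, phenyl in place of butyl gives a 2.7-fold higher number from compound 2 to compound 4 (0.44 log units; beyond the scatter), so the lower number seen with butyl does not carry over to phenyl. Phenyl in place of hydrogen gives a 1.1-fold lower number from compound 1 to compound 4 (0.04 log units; within the scatter), which leaves hydrogen and phenyl unseparated at this carbon while the isopropyl group stays in place, and among the three groups seen there only butyl stands apart. Nothing available accounts for the difference between the butyl chain and the phenyl ring.

Going by these compounds, it remains open whether the butyl result extends to a shorter chain such as ethyl, a longer chain such as hexyl, a saturated ring such as cyclohexyl, or an amine at this carbon. On these data alone, it is also open whether phenyl would behave the same way with hydrogen in place of isopropyl, the change that gives a lower number in the butyl pair of compound 2 and compound 3.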